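A few compounds are considered here, and "the series" means these few. Any claim that something is new, unique, unknown or untested is made for them only; others in the source may bear on it.

Compound 3 `CC/C=C\[C@H](C)[C@H](OC(N)=O)[C@@H](C)[C@H](O)[C@@H](C)C/C(C)=C\[C@H](C)[C@@H](O)[C@@H](C)/C=C\[C@@H](O)C[C@@H]1OC(=O)[C@H](C)C[C@H]1C` gives the lowest number of the three measured compounds in a functional assay on NCI/ADR-RES cells (Homo sapiens) for antiproliferative activity (a higher number here means a weaker inhibitor of growth, a lower number a stronger inhibitor of growth), at 140 nM; compound 2 `CC/C=C\[C@H](C)[C@H](OC(N)=O)[C@@H](C)[C@H](O)[C@@H](C)C/C(C)=C\[C@H](C)[C@@H](O)[C@@H](C)/C=C\[C@@H](O)C[C@H]1CCC(=O)O1` gives 730 nM and compound 1 `CC/C=C\[C@H](C)[C@H](OC(N)=O)[C@@H](C)[C@H](O)[C@@H](C)C/C(C)=C\[C@H](C)[C@@H](O)[C@@H](C)/C=C\[C@@H](O)C[C@@H]1OC(=O)NC[C@H]1C` gives 10000 nM. Compound 4 `CC/C=C\[C@H](C)[C@H](OC(N)=O)[C@@H](C)[C@H](O)[C@@H](C)C/C(C)=C\[C@H](C)[C@@H](O)[C@@H](C)/C=C\[C@H](O)C[C@@H]1CCC(=O)O1` carries the change (a group of 9 heavy atoms (6 carbon, 3 oxygen; one five-membered non-aromatic ring with 1 hetero atom) in place of a group of 12 heavy atoms (9 carbon, 3 oxygen; one six-membered non-aromatic ring with 1 hetero atom), on a double-bonded chain carbon bound to a double-bonded chain carbon). The step bearing most on this is a 5.2-fold lower number from compound 2 to compound 3 (0.72 log units; beyond the scatter), since the entering five-membered non-aromatic ring with 1 hetero atom is the kind found in compound 2, while compound 4 also shows 2 defined stereocentres where compound 3 shows 4. Reversing that step suggests a higher number for compound 4 in this assay, and the step is expected to be about a 7.1-fold higher number from compound 3 to compound 4 (0.85 log units; beyond the scatter). The value of compound 4 in this assay is therefore estimated at 1000 nM, with a range from 300 nM to 4000 nM.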

Compound 4, concentration for 50% growth inhibition: 10000 nM
Estimate against measurement, compound 4: 10-fold (1.00 log units) below, and the stated range ends below it.
By their numbers in this assay, from the lowest: compound 3; then compound 2; then compounds 1 and 4 (each within the scatter of the next).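

In this assay, a 14-fold higher number from compound 2 to compound 4 (1.14 log units; beyond the scatter) comes with no change in atoms or bonds, so configuration alone accompanies a large shift, which the earlier compounds could not show: the fact that compounds 2 and 4 differ only in the configuration as drawn

a 71-fold higher number from compound 3 to compound 4 (1.85 log units; beyond the scatter) adds the exchange of the six-membered ring for the five-membered ring to that shift, while no change at the digits printed from compound 1 to compound 4 (within the scatter) sets compound 4 against the nitrogen-containing ring.

The compounds shown do not separate the stereocentre at the saturated chain carbon from the one at the saturated ring carbon. From the compounds shown here alone, how a five-membered ring carrying an amine or a longer chain would behave in this assay remains open.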